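Swapping a chloro for an amino on a purine-like core

The source may report more compounds than this note shows. Statements on the series, on what has been measured and on what is new or still open speak of the compounds shown alone.

Compound 1, `ClCc1ccc(Cn2cnc3c(Cl)ncnc32)cc1`, gives 640 nM.
Compound 2, `ClCc1cccc(Cn2cnc3c(Cl)nc(Cl)nc32)c1`, gives 2510 nM.
Compound 3, `ClCc1ccccc1Cn1cnc2nc(Cl)nc(Cl)c21`, gives 3010 nM.

These three compounds were tested in a functional assay on SF-268 cells (Homo sapiens) for cytotoxicity, read by sulforhodamine B assay, with a stated time of 48 h; a lower number here means a stronger inhibitor of growth, a higher number a weaker inhibitor of growth. Compound 2 stands second highest of the three numbers. Its nearest neighbour is compound 3, which lies within the usual scatter, so the two cannot be told apart; compound 1 lies furthest away, with a lower number that is beyond the scatter.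

Compound 4, `Nc1nc(Cl)c2ncn(Cc3cccc(CCl)c3)c2n1`, has not yet been measured. It differs from compound 2 in one place: amino in place of chloro on an aromatic carbon. Within the data shown here, no pair of measured compounds shows what such a swap does here, so the direction of the step is uncertain. The change is expected to be modest, and compound 4 is expected to stay close to compound 2, with the step of a 1.4-fold higher number from compound 2 to compound 4 (0.14 log units; within the scatter) estimated not to go far beyond the scatter. In this assay compound 4 is therefore expected at about 3500 nM, within a range from 1200 nM to 10000 nM.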

Compound 4, concentration for 50% growth inhibition: 3020 nM
For compound 4 the middle estimate is 1.2-fold (0.06 log units) above the measured one; the measured number falls inside the stated range.
By their numbers in this assay, from the lowest: compound 1; then compounds 2, 3 and 4 (each within the scatter of the next).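

In this assay, placing amino instead of chloro on the aromatic carbon between two ring nitrogen atoms gives a 1.2-fold higher number from compound 2 to compound 4 (0.08 log units; within the scatter) and so leaves the two compounds indistinguishable. Among these compounds, this is the first reading of any single swap on this core, and it shows that this carbon can carry either group, even though the amino brings 1 hydrogen-bond donor that the chloro lacks, without a change that can be told from the scatter. Nothing available explains why the swap makes so little difference.

From the compounds shown here alone, it remains open whether a larger group on this carbon, such as a methylamino or a methoxy, would also leave growth inhibition in place. The same amino swap on compound 3 could also read differently, so this single step cannot yet be taken as general.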